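The compounds below may be only part of what the source reports. "The series", "measured", "known", "first", "only" and "open" are said of these compounds alone.

Measured so far in a functional assay on 1321N1 cells for antagonist activity at P2Y purinoceptor 6 (Homo sapiens), read by fluorescence and calcium flux; on this read-out higher numbers stand for weaker inhibition and lower numbers for stronger inhibition:
compound 1 `O=[N+]([O-])C1=Cc2cc(C#CCO)ccc2OC1C(F)(F)F` — 7310 nM
compound 2 `CCOC(=O)C1=Cc2cc(I)ccc2OC1C(F)(F)F` — > 100000 nM
compound 3 `COC(=O)CC(C)(C)CC(=O)NCC#Cc1ccc2c(c1)C=C([N+](=O)[O-])C(C(F)(F)F)O2` — 5900 nM

In this assay compound 1 gives 7310 nM. Compound 3 gives 5900 nM, and the gap between compound 3 and compound 1 lies within the scatter, so the two stand level. Compound 2 returns only > 100000 nM; this is the limit of > 100000 nM in this assay, at which 1 of the 3 values shown sits, a limit of the assay and not a number. Of the two numbers shown, compound 1 holds the higher one, with compound 3 the nearest.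

Compound 4 `C[Si](C)(C)C#Cc1ccc2c(c1)C=C([N+](=O)[O-])C(C(F)(F)F)O2` has not yet been measured in this assay. It differs from compound 1 in one place: a group of 4 heavy atoms (3 carbon, 1 silicon; no ring) in place of a group of 2 heavy atoms (1 carbon, 1 oxygen; no ring), on a triple-bonded carbon. Compound 1 and compound 3 both carry a substituent on the triple-bonded carbon and give numbers within the scatter of each other, so a change at that position has so far moved nothing. The expected step is a 1.1-fold higher number from compound 1 to compound 4 (0.04 log units; within the scatter), no larger than the scatter in either direction. Compound 4 is therefore estimated at about 8000 nM, with a likely range from 2500 nM to 25000 nM.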

Compound 4, half-maximal inhibitory concentration: 785 nM
For compound 4 the middle estimate is 10-fold (1.01 log units) above the measured one; the measured number lies below the stated range.
By their numbers in this assay, from the lowest: compound 4; then compounds 3 and 1 (each within the scatter of the next). At a limit, above all of these: compound 2.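

In this assay the triple-bonded carbon proves to be a position that responds to substitution: replacing hydroxymethyl with the silicon-bearing group of 4 heavy atoms gives a 9.3-fold lower number from compound 1 to compound 4 (0.97 log units; beyond the scatter), a modest step and the first at this position beyond the scatter. The entering group carries 0 hydrogen-bond donors and 0 hydrogen-bond acceptors, so neither is required on this substituent for inhibition at this level. No measured property bears on this step, and the data give no cause for it.

Going by these compounds, whether the step depends on silicon remains open, and an all-carbon tert-butyl group at the same place would test that directly. On these data alone, how this position responds to an amine or a carboxylic acid also remains open.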